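The compounds below may be only part of what the source reports. "The series", "measured", "known", "first", "only" and "open" are said of these compounds alone.

In a functional assay on RKO cells (Homo sapiens) for inhibition, read by MTT assay, with a stated time of 48 h (on this read-out higher numbers stand for weaker inhibition and lower numbers for stronger inhibition), compound 1 `COc1ccc(N(C)c2nc(C)nc3ccccc23)cc1OCCC[Se]C#N` gives 799 nM. For the measured compounds named here, that value lies within the scatter of compound 2 `COc1ccc(N(C)c2nc(C)nc3ccccc23)cc1OCCCCCC[Se]C#N` at 1540 nM, and together these two sit at the upper end of the three numbers measured so far. Going by the values given here, compound 3 `Cc1nc(N(C)c2ccc([Se]C#N)c(C)c2)c2ccccc2n1`, which carries no such side chain, gives a far lower 17 nM, but no single-place step connects it to compound 1, so it says little here.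

The next compound is compound 4 `COc1ccc(N(C)c2nc(C)nc3ccccc23)cc1C(=O)OCCC[Se]C#N`. Its change from compound 1 is a group of 9 heavy atoms (5 carbon, 1 nitrogen, 2 oxygen, 1 selenium; no ring) in place of a group of 7 heavy atoms (4 carbon, 1 nitrogen, 1 oxygen, 1 selenium; no ring), on an aromatic carbon. The swap sits on an aromatic carbon of a six-membered aromatic ring of carbon only, ortho to a methoxy group and meta to a large group.

Among the compounds with values here, only one measured step bears on this, and it alters the same side chain: a 1.9-fold higher number from compound 1 to compound 2 (0.28 log units; within the scatter). That step stayed small, although it concerned chain length and not the link to the ring. Within the data shown here, no measured pair shows the link itself being changed, so the evidence is thin, and no shift beyond the scatter is expected. The estimated step is a 1.1-fold higher number from compound 1 to compound 4 (0.05 log units; within the scatter), with no clear direction expected. For compound 4 the estimated value is 900 nM, with an expected range from 300 nM to 2700 nM.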

Compound 4, half-maximal inhibitory concentration: 1140 nM
Estimate against measurement, compound 4: 1.3-fold (0.10 log units) below; the range from low to high includes it.
By their numbers in this assay, from the lowest: compound 3; then compounds 1, 4 and 2 (each within the scatter of the next).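

In this assay, for the compounds shown here, this is the first change to the link that joins the selenium-bearing chain to the ring, and it gives a 1.4-fold higher number from compound 1 to compound 4 (0.15 log units; within the scatter). At this aromatic carbon, ortho to a methoxy group, the group of 9 heavy atoms, with its added double bond and 3 hydrogen-bond acceptors, therefore takes the place of the group of 7 heavy atoms, with 2 hydrogen-bond acceptors, without a shift beyond the scatter; the comparison with the longer chain gives a 1.4-fold lower number from compound 2 to compound 4 (0.13 log units; within the scatter), so the position has now tolerated both a change of link and a change of chain length within the scatter in this small set of compounds. No measurement shown here bears on the reason for this flat response.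

From the compounds shown here alone, it remains open whether an amide link at this aromatic carbon, or an amine or a carboxylic acid in place of the selenium-bearing chain end, would move the number beyond the scatter. The compounds shown also leave open whether a longer chain on the carbonyl link would stay as close as the longer chain on the oxygen link did in a 1.9-fold higher number from compound 1 to compound 2 (0.28 log units; within the scatter).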